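Two diaryl oxindole sulfonic acid and tert-butyl analogues, hydroxy added

The source may report more compounds than this note shows. Statements on the series, on what has been measured and on what is new or still open speak of the compounds shown alone.

Measured compounds:
compound 1, `O=C1Nc2ccc(S(=O)(=O)O)cc2C1(c1ccccc1)c1ccccc1`, 9000 nM
compound 2, `CC(C)(C)c1ccc(C2(c3ccccc3)C(=O)Nc3ccccc32)cc1`, 8000 nM

In a functional assay on cells (Lung cancer cell line, Homo sapiens) for antiproliferative activity (on this read-out higher numbers stand for weaker inhibition of growth and lower numbers for stronger inhibition of growth), compound 1 gives 9000 nM. Compound 2 carries a tert-butyl group instead of the sulfonic acid of compound 1 and on a different ring; in this assay compound 2 gives 8000 nM. Within the data shown here, these two numbers lie within the usual scatter of each other, so neither compound can be set above the other on this read-out, and the pair yields no step that could be read.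

Compound 3, `CC(C)(C)c1ccc(C2(c3ccc(O)cc3)C(=O)Nc3ccccc32)cc1`, has not been measured. It differs from compound 2 by hydroxy in place of hydrogen on an aromatic carbon. Among the measured compounds shown here, no measured pair here shows what such a change does, so the expectation must rest on the single value of compound 2 alone. With nothing to point in either direction, the writer expects the step of a 1.1-fold lower number from compound 2 to compound 3 (0.06 log units; within the scatter) to stay within the scatter, with no move beyond it in either direction. Compound 3 is therefore estimated at 7000 nM, with a likely range from 2500 nM to 20000 nM.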

Compound 3, concentration for 50% growth inhibition: 14000 nM
Beside the measured number, compound 3's estimate is 2.0-fold (0.30 log units) below it, within the range that was stated.
By their numbers in this assay, from the lowest: compounds 2, 1 and 3 (each within the scatter of the next).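

In this assay, among these compounds, the change from phenyl to 4-hydroxyphenyl gives a 1.8-fold higher number from compound 2 to compound 3 (0.24 log units; within the scatter), the first step that can be read, as the earlier pair differed in more than one place. It shows that at this position, on an aromatic carbon of a six-membered aromatic ring of carbon only and para to a large group, hydroxy in place of hydrogen brings no shift that can be told apart from repeat measurement, although the change adds a hydrogen-bond donor and acceptor. Nothing measured alongside these numbers offers an explanation for this result.

The compounds shown leave open whether an amine, a carboxylic acid or a methoxy group at this same place would give a step beyond the scatter, or would likewise stay within it. They also leave open whether hydroxy would read the same way without the tert-butyl group, as compound 3 is the only compound shown that carries hydroxy and this single step is all there is on the change.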